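This account rests on a few compounds, and the source may have more. Where it says the series, first, only, none or still open, it means among the compounds named here.

In an assay on HEK293 cells for displacement of a labelled ligand from growth hormone secretagogue receptor type 1 (Homo sapiens), with a stated time of 60 min (a higher number here means a weaker inhibitor, a lower number a stronger inhibitor), compound 1 `CN1CCN(CCCS(=O)(=O)c2ccc3nc(NC(=O)NC(=O)c4cc(C5CC5)ccc4Cl)sc3c2)CC1` gives 0.33 nM, and compound 2 `CN1CCN(CCCS(=O)(=O)c2ccc3nc(NC(=O)NC(=O)c4cc(N5CCCC5)ccc4Cl)sc3c2)CC1` gives 0.29 nM. The step of a 1.1-fold lower number from compound 1 to compound 2 (0.06 log units; within the scatter) is within the scatter, so on these two numbers compound 2 stands alongside compound 1 rather than apart from it. Compound 3 `Cc1ccn(-c2ccc(Cl)c(C(=O)NC(=O)Nc3nc4ccc(S(=O)(=O)CCCN5CCN(C)CC5)cc4s3)c2)n1` changes only the group at that same position: 3-methyl-1H-pyrazol-1-yl in place of pyrrolidin-1-yl on an aromatic carbon. Within the data shown here, the one measured step at this position bears on it and was within the scatter, so the change from compound 2 to compound 3 is expected to be small, a 1.4-fold higher number from compound 2 to compound 3 (0.14 log units; within the scatter). Compound 3 is therefore estimated at 0.4 nM in this assay, between 0.15 nM and 1.2 nM.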

Compound 3, half-maximal inhibitory concentration: 0.53 nM
Compound 3: middle estimate off by 1.3-fold (0.12 log units), on the low side; low and high end bracket the measured number.
By their numbers in this assay, from the lowest: compounds 2, 1 and 3 (each within the scatter of the next).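

In this assay, an aromatic ring carrying a methyl group replaces the non-aromatic rings at this position, giving a 1.8-fold higher number from compound 2 to compound 3 (0.26 log units; within the scatter) and a 1.6-fold higher number from compound 1 to compound 3 (0.21 log units; within the scatter). Thus, the position on the carbon ring para to a chloro group takes 3-methyl-1H-pyrazol-1-yl, pyrrolidin-1-yl and cyclopropyl with no difference that stands clear of the scatter. No evidence is available on why these groups read alike. All three groups are small rings, so a carboxylic acid, an open-chain amine or a longer alkyl chain here remains untested in the compounds shown.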